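From Propyl to Tert-Butyl Without a Measured Starting Point

A few compounds are considered here, and "the series" means these few. Any claim that something is new, unique, unknown or untested is made for them only; others in the source may bear on it.

In an ADME assay on microsomes from liver (Homo sapiens) for metabolic stability, with a stated time of 30 min (a lower number here means that less of the compound is left, a higher number that more of the compound is left), compound 1 `CC(C)[C@@H](CO)n1cc(C(=O)O)c(=O)c2cc(Cc3cccc(Cl)c3F)cnc21` gives 99%. Compound 2 `COc1nc(Cc2cccc(Cl)c2F)cc2c(=O)c(C(=O)O)cn([C@H](CO)C(C)C)c12` has the entry "not determined" (no result reported) in this assay. Among the measured compounds shown here, compound 3 `CCC[C@@H](CO)n1cc(C(=O)O)c(=O)c2cc(Cc3cccc(Cl)c3F)c(OC)nc21` has the same kind of entry, "not determined" (no result reported), so it has no number of its own and neither does the one other compound without a result. Compound 4 `COc1nc2c(cc1Cc1cccc(Cl)c1F)c(=O)c(C(=O)O)cn2[C@H](CO)C(C)(C)C` carries a single change against compound 3: tert-butyl in place of propyl on a saturated chain carbon bound to an aromatic nitrogen and a saturated chain carbon, with tert-butyl in place of propyl on a saturated chain carbon bound to an aromatic nitrogen and a saturated chain carbon. For the measured compounds named here, no measured step shows what this change does. A step beyond the scatter is not expected, and any shift is expected to be downward, since compound 1 at 99% leaves little room above. For compound 4 the expected value is 88%, with an estimated range from 65% to 100%.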

Compound 4, percent of the compound remaining: 82%
Beside the measured number, compound 4's estimate is 6 percentage points above it; the range from low to high includes it.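

Among the compounds shown here, no new step between compound 3 and compound 4 can be read in this assay from these results. The compounds shown leave open what replacing propyl with tert-butyl does to the percent remaining, and no evidence bears on compound 4's result.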